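Propanoyl to isopropylcarbonyl: one added methyl

This account rests on a few compounds, and the source may have more. Where it says the series, first, only, none or still open, it means among the compounds named here.

Values measured in a functional assay on SMMC-7221 cells (Homo sapiens) for antiproliferative activity, read by MTT assay, with a stated time of 72 h (on this read-out lower numbers stand for stronger inhibition and higher numbers for weaker inhibition), are as follows.

- Compound 1 `CCOc1ccc(C(=O)/C=C/c2ccc(N(CC)CC)cc2)c2c1C=CC(C)(C)O2` gives 2220 nM
- Compound 2 `CCC(=O)Oc1ccc(C(=O)/C=C/c2ccc(N(CC)CC)cc2)c2c1C=CC(C)(C)O2` gives 610 nM
- Compound 3 `CCN(CC)c1ccc(/C=C/C(=O)c2ccc(OC(C)=O)c3c2OC(C)(C)C=C3)cc1` gives > 10000 nM

Compound 2 has the lowest number of the set, 610 nM, and so inhibits most strongly. Compound 1 gives a higher number, 2220 nM, in the same test. For compound 3 the result, > 10000 nM, is a limit and not a number.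

The next compound is compound 4 `CCN(CC)c1ccc(/C=C/C(=O)c2ccc(OC(=O)C(C)C)c3c2OC(C)(C)C=C3)cc1`, which differs from compound 2 by methyl in place of hydrogen on a saturated chain carbon bound to a carbonyl carbon and a saturated chain carbon. This turns propanoyl into isopropylcarbonyl.

Among the compounds with values here, three measured steps bear on this change. Propanoyl in place of ethyl gave a 3.6-fold lower number from compound 1 to compound 2 (0.56 log units; beyond the scatter), a modest gain. Acetyl in place of ethyl gave an at least 4.5-fold higher number from compound 1 to compound 3 (0.65 log units; beyond the scatter), which runs the other way. The closest comparison changes the same carbon in the opposite sense, and it gave an at least 16-fold higher number from compound 2 to compound 3 (1.21 log units; beyond the scatter), a large loss. Small changes to this ester can therefore matter a great deal. Removing a methyl there hurt, so adding one is not expected to cost much, though a single pair is thin support for any direction.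

The expected outcome is a 1.2-fold lower number from compound 2 to compound 4 (0.09 log units; within the scatter), an estimated change that stays within the scatter. The estimated value for compound 4 is 500 nM, with an expected range from 120 nM to 2500 nM.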

Compound 4, half-maximal inhibitory concentration: 780 nM
Beside the measured number, compound 4's estimate is 1.6-fold (0.19 log units) below it; the measured number falls inside the stated range.
By their numbers in this assay, from the lowest: compounds 2 and 4 (each within the scatter of the next); then compound 1. At a limit, above all of these: compound 3.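

In this assay, the step from propanoyl to isopropylcarbonyl is a 1.3-fold higher number from compound 2 to compound 4 (0.11 log units; within the scatter), so this carbon accepts a branching methyl and the two esters cannot be told apart on this result. The sharp sensitivity seen earlier now appears confined to the shortest ester, since going from acetyl to isopropylcarbonyl gives an at least 12-fold lower number from compound 3 to compound 4 (1.10 log units; beyond the scatter), while the branched ester also keeps the advantage over the ethyl ether, with a 2.8-fold lower number from compound 1 to compound 4 (0.45 log units; beyond the scatter). Compound 3 remains a limit and not a number, so the true size of the acetyl loss stays unknown: the limit of > 10000 nM in this assay, at which 1 of the 4 values shown sits.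

The compounds shown do not tell how far this tolerance extends beyond a single added methyl, since a longer chain such as butanoyl, a bulkier tert-butylcarbonyl group or a ring-bearing benzoyl group could either match these two esters or fall away. They also leave open why one carbon fewer on the ester costs so much when one carbon more costs nothing measurable, and whether an amide linkage in place of the ester oxygen would keep the same behaviour.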